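Weak Agonists of a Fatty Acid Receptor: Swapping the Distal Aryl

The source may report more compounds than this note shows. Statements on the series, on what has been measured and on what is new or still open speak of the compounds shown alone.

Measured so far:
compound 1, `Cn1ccnc1[C@@H](CC(=O)O)c1ccc(OCc2cccc(-c3ccc(Cl)cc3Cl)c2)cc1`: 30000 nM
compound 2, `Cc1ccc(F)cc1-c1cccc(COc2ccc([C@H](CC(=O)O)c3nccn3C)cc2)c1`: 42000 nM

Both compounds share a core and differ only in the aryl group that sits on the benzyl ether. In an assay on CHO cells for agonist activity at Free fatty acid receptor 1 (Homo sapiens), read by luminescence, with a stated time of 20 s, in the presence of a further agent that is not named here (on this read-out lower numbers stand for an effect already at smaller amounts and higher numbers for an effect only at larger amounts of compound), compound 1 gives 30000 nM, and compound 2 gives 42000 nM. Going by the values given here, the one step between them, a 1.4-fold higher number from compound 1 to compound 2 (0.15 log units; within the scatter), is within the scatter, so the two values cannot be ordered. Compound 2 thus stands at the higher of the two numbers, but only nominally, with compound 1 as its nearest neighbour.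

Compound 3, `Cn1ccnc1[C@@H](CC(=O)O)c1ccc(OCc2cccc(-c3ccccc3Cl)c2)cc1`, has not yet been measured. The change from compound 2 is 2-chlorophenyl in place of 5-fluoro-2-methylphenyl on an aromatic carbon. Among the compounds with values here, the only comparable step, a 1.4-fold higher number from compound 1 to compound 2 (0.15 log units; within the scatter), also exchanged this aryl group and moved the number no further than the scatter; it is therefore expected that the step of a 1.1-fold lower number from compound 2 to compound 3 (0.04 log units; within the scatter) will likewise stay within the scatter. Compound 3 is accordingly expected to give about 38000 nM in this assay, within a range of 13000 nM to 110000 nM.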

Compound 3, half-maximal effective concentration: 56000 nM
Compound 3: the middle estimate sits 1.5-fold (0.17 log units) below what was measured; low and high end bracket the measured number.
By their numbers in this assay, from the lowest: compounds 1, 2 and 3 (each within the scatter of the next).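

In this assay, both new steps stay within the scatter: the exchange of the whole aryl group (a 1.3-fold higher number from compound 2 to compound 3 (0.12 log units; within the scatter)) and the removal of a single chlorine (a 1.9-fold higher number from compound 1 to compound 3 (0.27 log units; within the scatter)). The second step is the new information, since it changes one substituent rather than the whole aryl group: hydrogen in place of chloro, taking 2,4-dichlorophenyl to 2-chlorophenyl, gives no difference that can be read, and so the three aryl groups at this position, meta to a large group, cannot be ordered. Nothing available bears on this result.

The compounds shown leave open whether an amine or a methoxy group on this aryl ring would move the number beyond the scatter. They also leave open whether a pyridine in place of this ring would do so.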